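The compounds below may be only part of what the source reports. "The series", "measured", "known", "first", "only" and "open" are said of these compounds alone.

Measured compounds:
- compound 1 `CC(C)(C)OC(=O)c1cccc(NC(=O)C2CCCN(C(=O)c3cc(C(F)(F)F)cc(C(F)(F)F)c3)C2)c1`: 0%
- compound 2 `O=C(Nc1ccc(Cl)cc1)C1CCCN(C(=O)c2cccc([N+](=O)[O-])c2)C1`: 0%

The account follows the change from compound 1 to compound 3. In an ADME assay on PC-3 cells (Homo sapiens) for cytotoxicity, read by WST assay, tested at 100 uM (on this read-out higher numbers stand for more inhibition at the one concentration tested (going by the name of the read-out) and lower numbers for less inhibition), compound 1 gives 0%, and compound 2 gives 0% in the same assay. Compound 1 is thus level with compound 2 at the digits shown; the two values sit within the scatter of each other, so neither can be called more or less cytotoxic than the other. The inhibition in this assay is level for both at the tested concentration.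

Compound 3 `O=C(Nc1cccc(S(=O)(=O)N2CCCC2)c1)C1CCCN(C(=O)c2cc(C(F)(F)F)cc(C(F)(F)F)c2)C1` has not yet been tested in this assay. It differs from compound 1 by one change: (pyrrolidin-1-yl)sulfonyl in place of tert-butoxycarbonyl on an aromatic carbon. The shared core and the bis-trifluoromethyl benzoyl part of compound 1 are kept.

For the measured compounds named here, no step between measured compounds has been recorded here, so there is no directional trend to lean on. Since compound 1 gives 0% and compound 2 gives 0%, the expectation is that the change brings nothing beyond the scatter. Compound 3 is therefore estimated at 0% in this assay, within a range from -10% to 15%, a step of no change at the digits printed from compound 1 to compound 3 (within the scatter) that is expected to stay inside the usual scatter.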

Compound 3, a percentage reported as inhibition, at one concentration (the size of the read-out at that concentration, not a potency): 0%
The estimate for compound 3 equals the measured number at the digits printed; the range from low to high includes it.
By their numbers in this assay, from the lowest: compounds 1, 2 and 3 (each within the scatter of the next).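

For the compounds shown here, putting (pyrrolidin-1-yl)sulfonyl in place of tert-butoxycarbonyl on an aromatic carbon gives no change at the digits printed from compound 1 to compound 3 (within the scatter) in this assay, the first reading of a change at a single place, which compounds 1 and 2 alone could not give. At this position, on a six-membered aromatic ring of carbon only and meta to a large group, a group with no ring gives way to one carrying a five-membered non-aromatic ring, with the shared core and the bis-trifluoromethyl benzoyl part kept, and compound 3 gives 0%. Nothing at hand bears on why the read-out stays where it is.

With all the compounds shown at the same value, they do not tell whether any group at this position can move the read-out in this assay. As far as these compounds go, it stays open whether an amine or a carboxylic acid on this aromatic carbon, or a different group in place of the bis-trifluoromethyl benzoyl part, would take a compound away from the value of compound 3 at 0%.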